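The compounds below may be only part of what the source reports. "The series", "measured", "known", "first", "only" and "open" are said of these compounds alone.

Measured so far:
compound 1 `CC[C@H](C)[C@H](N)CN(C(=O)[C@@H]1C[C@H]1c1ccncc1)c1ccc(-c2ccccc2)cc1`: 1500 nM
compound 2 `CC[C@H](C)[C@H](N)CN(C(=O)[C@@H]1C[C@H]1c1nccs1)c1ccc(-c2ccccc2)cc1`: 210 nM

Both numbers come from a functional assay for agonist activity at G protein-coupled receptor 88 (Homo sapiens), read by HTRF and cAMP accumulation; a higher number here means that more compound is needed for the effect, a lower number that less compound is needed. For the measured compounds named here, compound 2 gives the lowest of the two numbers; the only neighbour is compound 1, reached by the step of a 7.1-fold lower number from compound 1 to compound 2 (0.85 log units; beyond the scatter), a modest change but beyond the scatter.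

Compound 3 `CC[C@H](C)[C@H](N)CN(C(=O)[C@@H]1C[C@H]1c1ccsc1)c1ccc(-c2ccccc2)cc1` is the next analogue. It differs from compound 2 in one place: thiophen-3-yl in place of 1,3-thiazol-2-yl on a saturated ring carbon. Going by the values given here, no measured step concerns a five-membered ring with a single hetero atom, so the one step from compound 1 to compound 2 bears on it only loosely, as a sign that the identity of the aromatic ring on the saturated ring carbon can move the number well beyond the scatter. With that precedent, and with the loss of one hydrogen-bond acceptor, the expected outcome for compound 3 is a step of a 2.4-fold higher number from compound 2 to compound 3 (0.38 log units; beyond the scatter) toward a somewhat higher number, with wide uncertainty. The estimate for compound 3 is 500 nM, within 150 nM to 1800 nM.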

Compound 3, half-maximal effective concentration: 450 nM
Beside the measured number, compound 3's estimate is 1.1-fold (0.05 log units) above it; the measured number falls inside the stated range.
By their numbers in this assay, from the lowest: compound 2; then compound 3; then compound 1.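

In this assay, the step of a 2.1-fold higher number from compound 2 to compound 3 (0.33 log units; beyond the scatter) shows that 1,3-thiazol-2-yl and thiophen-3-yl, both five-membered aromatic rings of 5 heavy atoms, are not interchangeable on this saturated ring carbon of the three-membered ring. The step of a 3.3-fold lower number from compound 1 to compound 3 (0.52 log units; beyond the scatter) puts thiophen-3-yl in the middle of the order, so a five-membered ring with a single hetero atom stays clear of pyridin-4-yl while 1,3-thiazol-2-yl remains lowest of the three. Nothing at hand accounts for either step.

The three compounds cannot separate the ring nitrogen of 1,3-thiazol-2-yl from the point at which the ring is attached, since the two change together here. Also open, on these data alone, is whether the order extends to phenyl, thiophen-2-yl or 1,3-oxazol-2-yl on the same carbon.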